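Methoxy on the anilide of a pyrazolyl dihydropyrimidinone series

A few compounds are considered here, and "the series" means these few. Any claim that something is new, unique, unknown or untested is made for them only; others in the source may bear on it.

Compound 1 `CCOC(=O)C1=C(C)NC(=S)NC1c1cn(-c2ccccc2)nc1-c1ccccc1` gives 42000 nM in a functional assay on MCF7 cells (Homo sapiens) for inhibition, read by sulforhodamine B assay, with a stated time of 24 h; a lower number here means a stronger inhibitor of growth, a higher number a weaker inhibitor of growth. Compound 2 `CC1=C(C(=O)Nc2ccccc2)C(c2cn(-c3ccccc3)nc2-c2ccccc2)NC(=O)N1` gives 80600 nM in this assay, and compound 3 `CC1=C(C(=O)Nc2ccccc2)C(c2cn(-c3ccccc3)nc2-c2ccc(Cl)cc2)NC(=O)N1` gives 65500 nM. Compound 3 sits between compound 2 and compound 1, and all three numbers lie within the usual scatter of one another. Within the data shown here, the one step in the set, a 1.2-fold lower number from compound 2 to compound 3 (0.09 log units; within the scatter), stays within the scatter.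

Compound 4 `COc1ccc(NC(=O)C2=C(C)NC(=O)NC2c2cn(-c3ccccc3)nc2-c2ccc(Cl)cc2)cc1` differs from compound 3 by methoxy in place of hydrogen on an aromatic carbon. Among the measured compounds shown here, no measured step bears on a methoxy at this place; the only substituent step, the chloro one, is within scatter. The change is expected to give a 1.1-fold lower number from compound 3 to compound 4 (0.04 log units; within the scatter). Compound 4 is estimated at 60000 nM, with a range from 25000 nM to 150000 nM.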

Compound 4, concentration for 50% growth inhibition: 69700 nM
Compound 4: middle estimate off by 1.2-fold (0.07 log units), on the low side; measured number inside the range.
By their numbers in this assay, from the lowest: compounds 1, 3, 4 and 2 (each within the scatter of the next).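

In this assay, going from phenylcarbamoyl to (4-methoxyphenyl)carbamoyl gives a 1.1-fold higher number from compound 3 to compound 4 (0.03 log units; within the scatter) and so adds no measurable difference at this place. Among these compounds, the anilide ring thus takes a methoxy para to a large group with the two numbers indistinguishable, a first reading at this position. No outside data bear on this result.

On these data alone, whether an amine, a carboxylic acid or a longer alkoxy chain at this place would move the number beyond the scatter remains open. Also open, as far as these compounds go, is whether methoxy reads the same on the anilide of compound 2, which lacks the chloro.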